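Replacing 3-isopropylphenyl with 1,3-thiazol-2-yl on an amide-type nitrogen

This account rests on a few compounds, and the source may have more. Where it says the series, first, only, none or still open, it means among the compounds named here.

Of the compounds shown here, three sharing one core have been measured in a functional assay on SMMC-7721 cells (Homo sapiens) for inhibition, read by MTT assay, with a stated time of 48 h; on this read-out higher numbers stand for weaker inhibition and lower numbers for stronger inhibition. Compound 1 (`Cc1ccc(NC(=O)Nc2cccc(-c3cccc4[nH]nc(N)c34)c2)cc1Cl`), with 3-chloro-4-methylphenyl on an amide-type nitrogen, gives 510 nM. Compound 2 (`Nc1n[nH]c2cccc(-c3cccc(NC(=O)Nc4ccc(F)c(F)c4)c3)c12`), with 3,4-difluorophenyl there, gives 5880 nM. Compound 3 (`CC(C)c1cccc(NC(=O)Nc2cccc(-c3cccc4[nH]nc(N)c34)c2)c1`), with 3-isopropylphenyl, gives 280 nM. Compound 3 therefore shares the low group of the three with compound 1, the step between them being a 1.8-fold lower number from compound 1 to compound 3 (0.26 log units; within the scatter). Against compound 2 the gap is clear, at a 21-fold lower number from compound 2 to compound 3 (1.32 log units; beyond the scatter).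

Compound 4 (`Nc1n[nH]c2cccc(-c3cccc(NC(=O)Nc4nccs4)c3)c12`) has not yet been measured. The change is 1,3-thiazol-2-yl in place of 3-isopropylphenyl on an amide-type nitrogen: one five-membered aromatic ring with 2 hetero atoms replaces one six-membered aromatic ring of carbon only. Every measured step swaps one substituted phenyl for another, so none tests this replacement directly. They do show that a change at this nitrogen alone can move the number a long way, as in a 12-fold higher number from compound 1 to compound 2 (1.06 log units; beyond the scatter). With compound 3 at 280 nM already in the low group, a higher number looks the likelier direction in this assay. The step expected is an 8.9-fold higher number from compound 3 to compound 4 (0.95 log units; beyond the scatter), which would lie beyond the scatter. For compound 4 the estimate is 2500 nM, with an expected range from 600 nM to 10000 nM.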

Compound 4, half-maximal inhibitory concentration: 550 nM
Estimate against measurement, compound 4: 4.5-fold (0.66 log units) above, and the stated range ends above it.
By their numbers in this assay, from the lowest: compounds 3, 1 and 4 (each within the scatter of the next); then compound 2.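

In this assay, the 1,3-thiazol-2-yl group gives a 2.0-fold higher number from compound 3 to compound 4 (0.29 log units; within the scatter) and a 1.1-fold higher number from compound 1 to compound 4 (0.03 log units; within the scatter), so at this amide-type nitrogen a five-membered aromatic ring with 2 hetero atoms can stand in for a substituted six-membered aromatic ring of carbon only without leaving the scatter of the two best-placed phenyl compounds. Compound 2 is the one that goes against any simple reading by ring type: the step of an 11-fold lower number from compound 2 to compound 4 (1.03 log units; beyond the scatter) shows that the smaller heteroaromatic ring stays with compound 1 and compound 3, while 3,4-difluorophenyl alone stands apart among the four compounds. Nothing available accounts for why these groups group as they do, and the numbers alone cannot supply a reason.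

The compounds shown leave open whether the ring nitrogen or the sulfur of the 1,3-thiazol-2-yl group matters, since a thiophene ring or a pyridine ring at this nitrogen would be needed to separate the two. They also leave open whether any aromatic ring is required here at all, which an open butyl chain or a saturated cyclohexyl ring in its place would address.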